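The source may report more compounds than this note shows. Statements on the series, on what has been measured and on what is new or still open speak of the compounds shown alone.

Compound 1, whose structure is `CC(=O)OC[C@H]1O[C@H](O[C@]2(COC(C)=O)O[C@H](CO)[C@@H](O)[C@@H]2OC(=O)/C=C/c2ccc(O)cc2)[C@H](OC(C)=O)[C@@H](O)[C@@H]1O`, gives 3440 nM in a functional assay on MCF7 cells (Homo sapiens) for cytotoxicity, read by MTT assay, with a stated time of 2 days; a lower number here means a stronger inhibitor, a higher number a weaker inhibitor. Among the three compounds measured, compound 1 carries the highest number: compound 2 `CC(=O)OC[C@H]1O[C@H](O[C@]2(CO)O[C@H](CO)[C@@H](O)[C@@H]2OC(=O)/C=C/c2ccc(O)cc2)[C@H](O)[C@@H](OC(C)=O)[C@@H]1OC(C)=O` gives 2930 nM, which lies within the scatter of compound 1, so no order between these two can be claimed, while compound 3 `CC(=O)OC[C@H]1O[C@H](O[C@]2(COC(C)=O)O[C@H](CO)[C@@H](OC(C)=O)[C@@H]2OC(=O)/C=C/c2ccc(O)cc2)[C@H](O)[C@@H](O)[C@@H]1O` gives 620 nM, a gap beyond the scatter, so compound 3 is the stronger inhibitor of that pair. Compound 4, with structure `CC(=O)OC[C@H]1O[C@H](O[C@]2(COC(C)=O)O[C@H](CO)[C@@H](O)[C@@H]2OC(=O)/C=C/c2ccc(O)c(O)c2)[C@H](OC(C)=O)[C@@H](O)[C@@H]1O`, has not yet been measured in this assay. It differs from compound 1 in one place: hydroxy in place of hydrogen on an aromatic carbon. Among the compounds with values here, nothing among the measured compounds shows what this particular change does, since compounds 1, 2 and 3 differ from one another only in where the acetyl groups sit on the shared core and not on the aromatic ring. The change is small in counted atoms, and the expected step from compound 1 to compound 4 is therefore modest, a 1.4-fold lower number from compound 1 to compound 4 (0.14 log units; within the scatter), with no strong direction beyond the scatter. Compound 4 is estimated at 2500 nM, within a range from 900 nM to 7000 nM.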

Compound 4, half-maximal inhibitory concentration: 770 nM
Compound 4: middle estimate off by 3.2-fold (0.51 log units), on the high side; the measured number lies below the stated range.
By their numbers in this assay, from the lowest: compounds 3 and 4 (each within the scatter of the next); then compounds 2 and 1 (each within the scatter of the next).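

In this assay, hydroxy in place of hydrogen on an aromatic carbon, which turns the 4-hydroxyphenyl group into 3,4-dihydroxyphenyl, gives a 4.5-fold lower number from compound 1 to compound 4 (0.65 log units; beyond the scatter). Within the data shown here, compounds 1, 2 and 3 differ only in where the acetyl groups sit on the shared core, so this is the first result to show that a change on the aromatic ring itself, at this carbon ortho to a hydroxy group, can move the number beyond the scatter. No measurement available here accounts for the size of this step.

As far as these compounds go, it remains open whether a methoxy group, a fluorine atom or an amine on this same carbon would give a step of similar size. Also open, from the compounds shown here alone, is whether hydroxy added here would do the same with the acetyl groups placed as in compound 2 or compound 3.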